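Working notes: 2-methylphenyl to 2-methoxyphenyl

The compounds below may be only part of what the source reports. "The series", "measured", "known", "first", "only" and "open" are said of these compounds alone.

Measured so far in a functional assay on K562/A02 cells (Homo sapiens) for antiproliferative activity, read by MTT assay; on this read-out higher numbers stand for weaker inhibition and lower numbers for stronger inhibition:
compound 1 `Cc1ccccc1/C(=N/NC(=S)NCCCCCC(=O)NO)c1ccccc1` gives 4220 nM
compound 2 `C/C(=N\NC(=S)NCCCCCC(=O)NO)c1cccc(C(F)(F)F)c1` gives 890 nM
compound 3 `C/C(=N\NC(=S)NCCCCCC(=O)NO)c1cccc(C)c1` gives 3570 nM

Compound 1 and compound 3 lie within the scatter of each other at the high-number end of this small set. Compound 2 gives a lower number than either of them, and both gaps lie beyond the scatter.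

The next compound is compound 4 (`COc1ccccc1/C(=N/NC(=S)NCCCCCC(=O)NO)c1ccccc1`), not yet measured. It differs from compound 1 by methoxy in place of methyl on an aromatic carbon, ortho to a large group (methoxy in place of methyl on an aromatic carbon).

Among the measured compounds shown here, only one measured step concerns a group on an aromatic carbon (a 4.0-fold higher number from compound 2 to compound 3 (0.60 log units; beyond the scatter)). That step, methyl in place of trifluoromethyl, is modest. It sits on a different core from that of compound 1 and involves no methoxy, so it offers a rough scale for such swaps but no direction for this one. For the measured compounds named here, no measured compound carries methoxy.

The estimated step is small (a 1.1-fold lower number from compound 1 to compound 4 (0.05 log units; within the scatter)), and no change beyond the scatter is expected. The expectation therefore stays close to compound 1 (4220 nM), with a wide margin on both sides. The estimate for compound 4 is 3800 nM (expected range 1600 nM to 9000 nM).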

Compound 4, half-maximal inhibitory concentration: 2910 nM
Compound 4: the middle estimate sits 1.3-fold (0.12 log units) above what was measured; the range from low to high includes it.
By their numbers in this assay, from the lowest: compound 2; then compounds 4, 3 and 1 (each within the scatter of the next).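

In this assay, putting methoxy in place of methyl on an aromatic carbon, ortho to a large group, gives a 1.5-fold lower number from compound 1 to compound 4 (0.16 log units; within the scatter) and so leaves the number within the scatter, which shows that this position accepts the extra oxygen and the one added hydrogen-bond acceptor with no readable change. The only earlier step on an aromatic carbon, on a different core, was a 4.0-fold higher number from compound 2 to compound 3 (0.60 log units; beyond the scatter) and lay beyond the scatter, so not every swap of this kind in the series moves the number by that much, although that step and this one differ in both core and groups. Nothing measured here explains the result, and no supporting data on the cause are at hand.

On these data alone, whether a hydroxyl, an amine or an ethoxy group on this same aromatic carbon would also stay within the scatter of compound 1 remains open. Also open is whether trifluoromethyl, which compound 2 carries on its own core at 890 nM and which gives the lowest number shown, would lower the number on the core of compound 1.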